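The source may report more compounds than this note shows. Statements on the series, on what has been measured and on what is new or still open speak of the compounds shown alone.

Compound 1, `CN(C)CCn1cnnc1-c1cc(Oc2ccc(NC(=O)N/N=C/c3c(O)ccc4ccccc34)cc2F)ccn1`: 890 nM in a functional assay on NCI-H460 cells (Homo sapiens) for cytotoxicity, read by MTT assay, with a stated time of 72 h; a lower number here means a stronger inhibitor, a higher number a weaker inhibitor
Compound 2, `CN(C)CCn1cnnc1-c1cc(Oc2ccc(NC(=O)N/N=C/c3ccc(Cl)cc3)cc2F)ccn1`: 320 nM in this assay

For the measured compounds named here, compound 2 holds the lowest of the two numbers; the only other value, that of compound 1, is higher, and the step of a 2.8-fold lower number from compound 1 to compound 2 (0.44 log units; beyond the scatter) is modest but beyond the scatter. The next compound, compound 3, `CN(C)CCn1cnnc1-c1cc(Oc2ccc(NC(=O)N/N=C/c3ccc(O)cc3)cc2F)ccn1`, differs from compound 2 by hydroxy in place of chloro on an aromatic carbon. Going by the values given here, no measured step matches this change exactly: the one step in hand removed a hydroxy-bearing ring system and brought in a chloro-bearing phenyl in a single move, so it bears on the present change only loosely. Because the step of a 2.8-fold lower number from compound 1 to compound 2 (0.44 log units; beyond the scatter) lowered the number when the hydroxy-bearing group left, the reverse move on compound 3 is expected to raise the number somewhat, a 1.9-fold higher number from compound 2 to compound 3 (0.27 log units; within the scatter), with wide uncertainty. Compound 3 is therefore estimated at 600 nM, within a range from 200 nM to 2000 nM.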

Compound 3, half-maximal inhibitory concentration: 1780 nM
Estimate against measurement, compound 3: 3.0-fold (0.47 log units) below, within the range that was stated.
By their numbers in this assay, from the lowest: compound 2; then compounds 1 and 3 (each within the scatter of the next).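

In this assay, the exchange of chloro for hydroxy on the aromatic carbon para to a large group, taken alone, gives a 5.6-fold higher number from compound 2 to compound 3 (0.75 log units; beyond the scatter), so this single change is now seen apart from any change in the ring system. The step of a 2.0-fold higher number from compound 1 to compound 3 (0.30 log units; within the scatter) leaves the 4-hydroxyphenyl and 2-hydroxynaphthalen-1-yl compounds unseparated, and among the three, compound 2 with its 4-chlorophenyl stands apart from both hydroxy-bearing compounds. Nothing at hand accounts for the difference between chloro and hydroxy at this position.

The compounds shown leave open how bromo, methoxy or an amine on the same carbon would compare with chloro and hydroxy. They also leave open whether moving the chloro elsewhere on the ring would keep the number of compound 2.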